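Replacing difluoromethoxy with a trifluoroacetamidomethyl group

The compounds below may be only part of what the source reports. "The series", "measured", "known", "first", "only" and "open" are said of these compounds alone.

Of the compounds shown here, three sharing one core have been tested in an assay on isolated protein for inhibition of ubiquitin carboxyl-terminal hydrolase 7 (Homo sapiens), with stated times of 30 min and 2 h; on this read-out lower numbers stand for stronger inhibition and higher numbers for weaker inhibition. Compound 1 `Cn1nc2c(=O)n(CC3(O)CCN(Cc4ccc(-c5ccco5)cc4Cl)CC3)cnc2c1-c1ccc(C2(N)CC2)cc1` gives 66.1 nM, compound 2 `Cn1nc2c(=O)n(CC3(O)CCN(Cc4ccc(-c5ccco5)cc4Cl)CC3)cnc2c1-c1ccc(C(F)(F)F)cc1` gives 530 nM, and compound 3 `Cn1nc2c(=O)n(CC3(O)CCN(Cc4ccc(-c5ccco5)cc4Cl)CC3)cnc2c1-c1ccc(OC(F)F)cc1` gives 179 nM. On these numbers compound 3 stands second highest of the three: the step of a 2.7-fold higher number from compound 1 to compound 3 (0.43 log units; beyond the scatter) and the step of a 3.0-fold lower number from compound 2 to compound 3 (0.47 log units; beyond the scatter) both lie beyond the scatter, so the group on this aromatic carbon plainly influences the read-out. Compound 4 `Cn1nc2c(=O)n(CC3(O)CCN(Cc4ccc(-c5ccco5)cc4Cl)CC3)cnc2c1-c1ccc(CNC(=O)C(F)(F)F)cc1` keeps everything else unchanged and differs only here: (((trifluoromethyl)carbonyl)amino)methyl in place of difluoromethoxy on an aromatic carbon. Within the data shown here, none of the measured steps involves the entering group, so the steps of an 8.0-fold higher number from compound 1 to compound 2 (0.90 log units; beyond the scatter) and a 3.0-fold lower number from compound 2 to compound 3 (0.47 log units; beyond the scatter) serve only to show how far the numbers have moved when this one position was varied. Within that range a modest step in either direction, or none beyond the scatter, is plausible for compound 4. Compound 4 is therefore expected to give about 150 nM, within a range from 50 nM to 500 nM. This estimate corresponds to an expected step of a 1.2-fold lower number from compound 3 to compound 4 (0.08 log units; within the scatter).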

Compound 4, half-maximal inhibitory concentration: 2060 nM
Compound 4: the middle estimate sits 14-fold (1.14 log units) below what was measured; measured number above the stated range.
By their numbers in this assay, from the lowest: compound 1; then compound 3; then compound 2; then compound 4.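

With a 12-fold higher number from compound 3 to compound 4 (1.06 log units; beyond the scatter) in this assay and also a 3.9-fold higher number from compound 2 to compound 4 (0.59 log units; beyond the scatter) on the same read-out, this position clearly does not accept every group equally: the (((trifluoromethyl)carbonyl)amino)methyl group gives the weakest inhibition of the four compounds. The step of a 31-fold higher number from compound 1 to compound 4 (1.49 log units; beyond the scatter) separates two groups that both contain nitrogen, so the presence of nitrogen in the group does not alone set the number. Nothing measured here explains why the number rises so far.

Going by these compounds, what stays open is which part of the entering group goes with the weaker inhibition, the trifluoromethyl end or the amide link. A plain aminomethyl group, or an acetylaminomethyl group without fluorine, at this position would help to separate these two parts.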